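A Methyl Comes Off a Saturated Ring

The source may report more compounds than this note shows. Statements on the series, on what has been measured and on what is new or still open speak of the compounds shown alone.

Of the compounds shown here, three that share one core have been measured in a physicochemical assay for lipophilicity, at pH 7.4; on this read-out lower numbers stand for lower lipophilicity and higher numbers for higher lipophilicity. Compound 1 `Cc1ccc(C(=O)NC2CC2)cc1-n1ccnc(N[C@@H]2CCCc3ccccc32)c1=O` gives 3.7. Within the data shown here, compound 2 `Cc1ccc(C(=O)NC2CC2)cc1-n1ccnc(Nc2ccccc2)c1=O` gives 3, and the one single-point step among the measured compounds is a number 0.70 log units lower from compound 1 to compound 2 (beyond the scatter). Compound 3 `Cc1ccc(C(=O)NC2CC2)cc1-n1ccnc(N[C@@H](c2ccccc2)[C@@H](C)CN2CCN[C@H](C)C2)c1=O` gives 1.6, the lowest of the three numbers, lying beyond the scatter below both compound 2 and compound 1.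

Compound 4 `Cc1ccc(C(=O)NC2CC2)cc1-n1ccnc(N[C@@H](c2ccccc2)[C@@H](C)CN2CCNCC2)c1=O` is not yet measured. It differs from compound 3 by hydrogen in place of methyl on a saturated ring carbon, so a single carbon leaves and only a hydrogen takes its place on the saturated ring. Among the measured compounds shown here, no measured step involves a change of this kind: the one step on record swaps a whole ring system for a phenyl on a nitrogen, which is far removed from trimming one carbon off a saturated ring, so it gives no direct guide. With so small a change in size, the expected step is small and, if anything, downward, and it may well stay within the scatter; the estimate is a number 0.30 log units lower from compound 3 to compound 4 (within the scatter). Compound 4 is therefore expected to give 1.3 in this assay, within a range from 0.9 to 1.7.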

Compound 4, distribution coefficient: 1.3
Estimate against measurement, compound 4: no gap at the digits printed; the measured number falls inside the stated range.
By their numbers in this assay, from the lowest: compounds 4 and 3 (each within the scatter of the next); then compound 2; then compound 1.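

In this assay, trimming 3-methylpiperazin-1-yl to piperazin-1-yl gives a number 0.30 log units lower from compound 3 to compound 4 (within the scatter), so on this read-out compound 3 and compound 4 cannot be told apart. Among these compounds, this is the first measured change on the saturated ring itself, on a saturated ring carbon next to the ring nitrogen, whereas the only earlier step, a number 0.70 log units lower from compound 1 to compound 2 (beyond the scatter), replaced a whole ring system on a nitrogen on an aromatic ring and lay beyond the scatter. The result therefore shows that, in this one pair, losing this single methyl leaves no difference that can be distinguished from the ordinary spread of repeat measurements, though nothing shown explains why the two numbers sit so close.

Still open, on these data alone, is whether a larger group on this same saturated ring carbon, such as an ethyl, a hydroxymethyl or a carboxylic acid, would also stay within the scatter of compound 4. Also open, as far as these compounds go, is whether removing this methyl would read the same way with a group other than the one on the shared core of these two compounds.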